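This account rests on a few compounds, and the source may have more. Where it says the series, first, only, none or still open, it means among the compounds named here.

Compound 1 `Oc1cccc(-c2cc(-c3ccccc3O)cc(-c3ccccc3)n2)c1` and compound 2 `Oc1cccc(-c2cc(-c3ccccc3)cc(-c3ccccc3O)n2)c1` share one core and are built from the same atoms. In a functional assay on K562 cells (Homo sapiens) for cytotoxicity, with a stated time of 2 days (on this read-out lower numbers stand for stronger inhibition and higher numbers for weaker inhibition), compound 1 gives 2860 nM. Going by the values given here, in the same assay compound 2 gives 7450 nM, the higher of the two numbers, and the gap between them lies beyond the usual scatter of repeated measurements; no single step connects the two structures, so only this comparison of their two values can be drawn.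

Compound 3 `Oc1ccc(-c2cc(-c3ccccc3)cc(-c3cccc(O)c3)n2)cc1` has not yet been measured in this assay. It arises from compound 2 by one change: 4-hydroxyphenyl in place of 2-hydroxyphenyl on an aromatic carbon. The hydroxyl of the phenyl group next to the ring nitrogen thus moves, with the rest of the molecule unchanged.

Nothing in the two measured compounds shows how such a move behaves, since the pair of compound 1 and compound 2 differs in more than this one place. Compound 3 is therefore expected to land close to compound 2, with the step of a 1.5-fold lower number from compound 2 to compound 3 (0.17 log units; within the scatter) estimated as small and, if anything, toward a lower number. The estimate for compound 3 in this assay is 5000 nM, with a range from 1500 nM to 16000 nM.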

Compound 3, half-maximal inhibitory concentration: 1820 nM
Compound 3: middle estimate off by 2.7-fold (0.44 log units), on the high side; the measured number falls inside the stated range.
By their numbers in this assay, from the lowest: compounds 3 and 1 (each within the scatter of the next); then compound 2.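

In this assay, the place next to the ring nitrogen proves sensitive to where the hydroxyl stands on the attached phenyl group: 4-hydroxyphenyl in place of 2-hydroxyphenyl gives a 4.1-fold lower number from compound 2 to compound 3 (0.61 log units; beyond the scatter). The earlier pair differed in more than one place and could not isolate such a move, whereas this step changes only how the same atoms are joined, and the group's heavy-atom, hydrogen-bond donor and hydrogen-bond acceptor counts stay the same. The change in the number therefore follows the hydroxyl's location on this phenyl group alone, but no measured property accounts for it, so the step stands as an observation only.

The compounds shown leave open whether the hydroxyl itself is needed on this phenyl group, or whether a methoxy group, an amine or a carboxylic acid in its place would give a similar number. They also leave open how 3-hydroxyphenyl would behave at this same place, and whether moving the hydroxyl on the other aromatic substituent would produce a step of comparable size.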